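A few compounds are considered here, and "the series" means these few. Any claim that something is new, unique, unknown or untested is made for them only; others in the source may bear on it.

Compound 1 `CCn1c(=O)n(C2OC(CO)[C@@H](O)[C@H]2O)c2nc(N)nc(O)c21` stands highest of the two measured numbers: in a functional assay on the whole organism (B cells) with Mus musculus as the target (a lower number here means a smaller maximal response, a higher number a larger maximal response), compound 1 gives 82%, while compound 2 `C=CCn1c(=O)n(CCC(CCOCc2ccccc2)CCOCc2ccccc2)c2nc(N)nc(O)c21` gives 68%, a gap beyond the scatter. Compound 3 `Cn1c(=O)n(C2OC(CO)[C@@H](O)[C@H]2O)c2nc(N)nc(O)c21` differs from compound 1 by a single change, (hydrogen in place of methyl on a saturated chain carbon bound to an aromatic nitrogen). Going by the values given here, no measured pair shows this change, so the step from compound 1 to compound 3 in this assay is expected to be small, in either direction or none beyond the scatter. The expected step is a number 4 percentage points lower from compound 1 to compound 3 (within the scatter). For compound 3 the estimate in this assay is 78%, with a range from 62% to 92%.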

Compound 3, largest response reached (reported as maximal response), in percent of the reference or control that the assay uses: 99%
Compound 3: middle estimate off by 21 percentage points, on the low side, outside the stated range (above it).
By their numbers in this assay, from the lowest: compound 2; then compound 1; then compound 3.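

Going by these compounds alone, on the saturated chain carbon bound to an aromatic nitrogen, hydrogen in place of methyl (cut one bond further out, ethyl to methyl) is the first single-place change. In this assay it gives a number 17 percentage points higher from compound 1 to compound 3 (beyond the scatter), so this small change is not silent. Nothing at hand explains the step.

Open, as far as these compounds go, is whether a propyl group or a longer chain at this place would continue the direction seen with ethyl and methyl. Also open, from the compounds shown here alone, is whether the same change acts alike on cores carrying other groups.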